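The compounds below may be only part of what the source reports. "The series", "measured", "known", "first", "only" and "open" are said of these compounds alone.

Compound 1 `COc1cccc(COc2ccccc2/C=C/C=C2\SC(=S)NC2=O)c1`: 82%
Compound 2 `O=C1NC(=S)S/C1=C\C=C\c1ccccc1OCc1ccccc1`: 65%

For the measured compounds named here, in a functional assay on DLD-1 cells (Homo sapiens), read by microscopy and crystal violet staining, with a stated time of 20 h, tested at 10 ug/mL (a lower number here means less inhibition, a higher number more inhibition at the concentration tested (going by the name of the read-out)), compound 2 has the lowest of the two numbers; the one measured step, a number 17 percentage points lower from compound 1 to compound 2 (beyond the scatter), separates it from compound 1. Compound 3 `O=C1NC(=S)S/C1=C\C=C\c1ccccc1OCc1ccccc1Br` differs from compound 2 by bromo in place of hydrogen on an aromatic carbon. Going by the values given here, no measured step concerns a bromo group, so the only step on record, a number 17 percentage points lower from compound 1 to compound 2 (beyond the scatter), does not bear directly on this change, and it was modest in size. A step no larger than the usual scatter is therefore expected, no change at the digits printed from compound 2 to compound 3 (within the scatter), with wide uncertainty. Compound 3 is estimated to give 65% in this assay, between 45% and 85%.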

Compound 3, a percentage reported as inhibition, at one concentration (the size of the read-out at that concentration, not a potency): 78%
The estimate for compound 3 lay 13 percentage points below the measured number; measured number inside the range.
By their numbers in this assay, from the lowest: compound 2; then compounds 3 and 1 (each within the scatter of the next).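

In this assay a bromo group on the benzyl ring also moves the number, with a number 13 percentage points higher from compound 2 to compound 3 (beyond the scatter). Two different groups on this ring, 3-methoxy and 2-bromo, therefore both stand above the plain benzyl of compound 2, while the two substituted compounds stay close, with a number 4 percentage points lower from compound 1 to compound 3 (within the scatter). Nothing available explains this rise.

On these data alone, whether the gain depends on the group or on its place remains open. An amine or a carboxylic acid on this ring could follow the same trend or break it.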